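Removing a Chloro Group from Compound 1: What to Expect

The compounds below may be only part of what the source reports. "The series", "measured", "known", "first", "only" and "open" are said of these compounds alone.

Compound 1, `O=c1c(C(=S)Nc2ccccc2)coc2cc(Cl)ccc12`, gives 47% in a functional assay on OVCAR-3 cells (Homo sapiens) for inhibition, read by sulforhodamine B assay, with a stated time of 48 h, tested at 100 uM; on this read-out higher numbers stand for more inhibition of growth at the one concentration tested and lower numbers for less inhibition of growth.
Compound 2, `O=c1c(C2N=C(c3ccccc3)SS2)coc2ccc(Cl)cc12`, gives 71% in this assay.
Compound 3, `O=c1c(C2N=C(c3ccccc3)SS2)coc2cc(Cl)c(Cl)cc12`, gives 68% in this assay.

Compound 4, `O=c1c(C(=S)Nc2ccccc2)coc2ccccc12`, has not been measured. It differs from compound 1 by hydrogen in place of chloro on an aromatic carbon. The same kind of change is seen between two measured compounds: compound 2 differs from compound 3 by hydrogen in place of chloro on an aromatic carbon, and there the step was a number 3 percentage points higher from compound 3 to compound 2 (within the scatter). The surroundings are not identical, for in compound 3 the chloro that leaves sits ortho to a second chloro group, whereas in compound 1 no such neighbour is present. How the core of compound 1 differs from the core of compound 3 is not broken down here.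

Compound 1 stands lowest of the three measured numbers in this assay. Because the step of a number 3 percentage points higher from compound 3 to compound 2 (within the scatter) lay within the scatter, compound 4 is expected to land close to compound 1, with an estimated step of a number 2 percentage points lower from compound 1 to compound 4 (within the scatter). Compound 4 is therefore estimated at 45%, expected to fall between 30% and 62%.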

Compound 4, percent growth inhibition at one concentration: 58%
For compound 4 the middle estimate is 13 percentage points below the measured one; the measured number falls inside the stated range.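

On the core of compound 1, hydrogen in place of chloro on an aromatic carbon gives a number 11 percentage points higher from compound 1 to compound 4 (beyond the scatter) in this assay and so counts as a modest gain in growth inhibition on this core. Set beside the same change on the other core, this step cannot be told apart from the earlier one: the same change on two cores in this assay, a number 3 percentage points higher (within the scatter) from compound 3 to compound 2 and a number 11 percentage points higher (beyond the scatter) from compound 1 to compound 4, 8 percentage points apart, within the scatter of two such steps

So, across these two pairs, the change carries from one core to the other without a size difference that can be resolved, yet only the step on the core of compound 1 stands clear of the scatter. Two pairs do not show that the step has one fixed size across the series, nor do they explain why its size might vary.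

The compounds shown leave open what a fluoro group, a methoxy group or an amine would do in place of the chloro. They also leave open whether the same step would appear on any core beyond these two.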